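The source may hold more compounds than are shown below. What is called first, only, known or untested is meant among the compounds shown, and "the series" means these compounds.

The series shares the core of compound 1 `C/C=C1/[C@H](O[C@@H]2O[C@H](CO)[C@@H](O)[C@H](O)[C@H]2O)OC=C(C(=O)OC)[C@H]1CC(=O)OCc1ccc2c(c1)OCCO2`, which carries a 2,3-dihydro-1,4-benzodioxin-6-yl group on a saturated chain carbon bound to an oxygen next to a carbonyl group. In a functional assay on SK-BR-3 cells (Homo sapiens) for antiproliferative activity, read by MTT assay, with a stated time of 72 h (a lower number here means a stronger inhibitor, a higher number a weaker inhibitor), compound 1 gives > 15000 nM, a limit of the assay rather than a number. Compound 2 `C/C=C1/[C@H](O[C@@H]2O[C@H](CO)[C@@H](O)[C@H](O)[C@H]2O)OC=C(C(=O)OC)[C@H]1CC(=O)OCC` carries methyl in place of that group, and in this assay compound 2 gives > 15000 nM, again a limit. Going by the values given here, compound 3 `C/C=C1/[C@H](O[C@@H]2O[C@H](CO)[C@@H](O)[C@H](O)[C@H]2O)OC=C(C(=O)OC)[C@H]1CC(=O)OCCC(C)C`, carrying isobutyl there, gives 9020 nM in this assay, the only numerical value among the three. Compounds 1 and 2 sit at the limit of > 15000 nM in this assay, at which 2 of the 3 values shown sit. The steps of an at least 1.6-fold lower number from compound 1 to compound 3 (0.22 log units; that floor lies within the scatter) and an at least 1.6-fold lower number from compound 2 to compound 3 (0.22 log units; that floor lies within the scatter) are therefore readable only as floors, and each floor lies within the scatter, while the step that the two limits leave unreadable from compound 1 to compound 2 cannot be read at all.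

Compound 4 `C/C=C1/[C@H](O[C@@H]2O[C@H](CO)[C@@H](O)[C@H](O)[C@H]2O)OC=C(C(=O)OC)[C@H]1CC(=O)OCCCC` differs from compound 3 by hydrogen in place of methyl on a saturated chain carbon bound to two saturated chain carbons. This partly undoes the change that added isopropyl in place of hydrogen between compound 2 and compound 3, and that earlier change gave a floor within the scatter. Compound 4 is accordingly expected to show the step of a 1.3-fold higher number from compound 3 to compound 4 (0.12 log units; within the scatter) in this assay, a small rise that stays within the scatter, with a real chance that only a limit is returned. The estimate for compound 4 in this assay is 12000 nM, between 6000 nM and 22000 nM.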

Compound 4, half-maximal inhibitory concentration: > 15000 nM
Compound 4: only a limit was reported; the forecaster's own chance of this, stated with the estimate: 40%; middle value at least 1.2-fold (0.09 log units) from the limit.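

In this assay compound 4 gives > 15000 nM, which is a limit of the assay and not a number. Hydrogen in place of methyl on a saturated chain carbon bound to two saturated chain carbons gives an at least 1.6-fold higher number from compound 3 to compound 4 (0.22 log units; that floor lies within the scatter), so this change, which turns isobutyl into propyl at this position, is not shown to matter, since the floor of the step does not clear the scatter. The steps from compound 1 and compound 2 to compound 4 cannot be read, and compound 3 remains the only compound with a number, as the series gathers at a single limit: the limit of > 15000 nM in this assay, at which 3 of the 4 values shown sit.

The compounds shown leave open what values lie behind the limits of compound 1, compound 2 and compound 4, and so whether the methyl removed here has any real effect. From the compounds shown here alone, it also remains open whether a longer chain such as hexyl, or a chain ending in an amine or a carboxylic acid, would give a number in this assay that stands clear of the scatter.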